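Swapping a formyl tail for a dimethylamino tail on the core

The source may hold more compounds than are shown below. What is called first, only, known or untested is meant among the compounds shown, and "the series" means these compounds.

Compound 2 `Cn1nc(Cc2nnc(SCCCCCCCC(=O)Nc3ccc(Cl)cc3Cl)n2CCC=O)c2ccccc2c1=O` carries a formylmethyl chain on one aromatic nitrogen of the shared core. In an assay on NK92 cells for inhibition of interleukin-2 (Homo sapiens), read by AlphaScreen, with stated times of 30 min and 1 h (on this read-out higher numbers stand for weaker inhibition and lower numbers for stronger inhibition), compound 2 gives 960 nM, the highest of the two numbers that are not limits. Compound 1 `Cn1c(Cc2nn(C)c(=O)c3ccccc23)nnc1SCCCCCCCC(=O)Nc1ccc(Cl)cc1Cl`, which has a hydrogen in that position, gives 350 nM in this assay, and the step of a 2.7-fold higher number from compound 1 to compound 2 (0.44 log units; beyond the scatter) is therefore a modest weakening. Compound 3 `Cn1nc(Cc2nnc(SCC(=O)Nc3ccc(Cl)cc3Cl)n2CCC(=O)O)c2ccccc2c1=O`, with a much shorter sulfur-linked chain and an acid-bearing tail, reaches only the limit > 30000 nM in this assay, so its number is not known. Compound 4 `CN(C)CCCn1c(Cc2nn(C)c(=O)c3ccccc23)nnc1SCCCCCCCC(=O)Nc1ccc(Cl)cc1Cl` differs from compound 2 by (dimethylamino)methyl in place of formyl on a saturated chain carbon, two bonds along the chain from an aromatic nitrogen. For the measured compounds named here, only the step from compound 1 to compound 2 bears on this change, and it shows that extending this position costs a modest amount; nothing measured tells whether a basic amine tail behaves like a formyl tail. Compound 4 is therefore expected to sit close to compound 2, a step of a 1.4-fold lower number from compound 2 to compound 4 (0.14 log units; within the scatter), and its estimated value is 700 nM with a range from 200 nM to 2500 nM.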

Compound 4, half-maximal inhibitory concentration: > 30000 nM
Compound 4 was reported as a limit; the forecaster's own chance of this, stated with the estimate: 3%; at least 42-fold (1.63 log units) between middle value and limit.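

This position is far less forgiving than the modest cost of the formylmethyl chain suggested: in this assay, replacing formyl with (dimethylamino)methyl gives an at least 31-fold higher number from compound 2 to compound 4 (1.49 log units; beyond the scatter). Set against the hydrogen of compound 1, the 2-(dimethylamino)ethyl group gives an at least 85-fold higher number from compound 1 to compound 4 (1.93 log units; beyond the scatter). So a chain at this nitrogen can be tolerated with a modest loss or can come with a large one, depending on the group it carries. Compound 4 is reported only as a limit, not a number, so the full size of both steps stays unknown: the limit of > 30000 nM in this assay, at which 2 of the 4 values shown sit.

On these data alone, it remains open whether the loss follows from the amine nitrogen or from the longer tail as a whole. A plain butyl chain, or a chain of similar length ending in a hydroxyl group or an amide, would help separate these two readings.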